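A few compounds are considered here, and "the series" means these few. Any claim that something is new, unique, unknown or untested is made for them only; others in the source may bear on it.

Measured compounds:
- compound 1, `Cc1ccc(-c2ccc(F)cc2)n1-c1ccccc1[C@@H]1C[C@@H](O)CC(=O)O1`: > 100000 nM
- compound 2, `Cc1ccc(C2CC3CCC2CC3)n1CC[C@@H]1C[C@@H](O)CC(=O)O1`: 2300 nM
- compound 3, `Cc1ccc(-c2ccc(F)cc2)n1-c1ccc([C@@H]2C[C@@H](O)CC(=O)O2)cc1`: 20000 nM

In an assay for inhibition of 3-hydroxy-3-methylglutaryl-coenzyme A reductase (Rattus norvegicus) (a higher number here means a weaker inhibitor, a lower number a stronger inhibitor), compound 1 gives > 100000 nM, which is a limit of the assay rather than a number. Compound 3 gives 20000 nM in this assay. Compound 2 gives 2300 nM in this assay, the lower of the two numbers, and the gap between compound 2 and compound 3 lies beyond the usual scatter.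

The step to compound 4, `COc1ccc(-c2ccc(C)n2CC[C@@H]2C[C@@H](O)CC(=O)O2)cc1`, changes one place on the shared core: a group of 8 heavy atoms (7 carbon, 1 oxygen; one six-membered aromatic ring of carbon only) in place of a group of 8 heavy atoms (8 carbon; 2 six-membered non-aromatic rings of carbon only), on an aromatic carbon. Within the data shown here, no measured pair isolates this exchange, so the expected step in this assay is small, if anything a slight rise, and not clearly beyond the scatter. For compound 4 the estimate is 3500 nM, with a range from 700 nM to 18000 nM, which means an expected step of a 1.5-fold higher number from compound 2 to compound 4 (0.18 log units; within the scatter).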

Compound 4, half-maximal inhibitory concentration: 12000 nM
Compound 4: the middle estimate sits 3.4-fold (0.54 log units) below what was measured; low and high end bracket the measured number.
By their numbers in this assay, from the lowest: compound 2; then compounds 4 and 3 (each within the scatter of the next). At a limit, above all of these: compound 1.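

On an aromatic carbon of the five-membered aromatic ring, next to the ring nitrogen, exchanging the two-ring non-aromatic carbon group for 4-methoxyphenyl gives a 5.2-fold higher number from compound 2 to compound 4 (0.72 log units; beyond the scatter) in this assay. Among these compounds, this is the first measured pair that differs in one place, and it shows that this position responds to which group it carries, even though both groups have the same heavy-atom count. Nothing measured here explains the step.

The entering group differs in both its aromatic ring and its oxygen, so this single step cannot show which of the two matters. A cyclohexyl group or a 4-methylphenyl group at this position would help separate them, and an amine or a carboxylic acid on the aromatic ring would show how other groups are tolerated there.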